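The source may report more compounds than this note shows. Statements on the series, on what has been measured and on what is new or still open speak of the compounds shown alone.

Compound 1 `CCCCCC(=O)Nc1ccc2[nH]cc(C3CCN(C)CC3)c2n1` is the starting point of this account. In an assay for binding affinity to 5-hydroxytryptamine receptor 1F (Homo sapiens), read by radioligand binding (on this read-out higher numbers stand for weaker inhibition and lower numbers for stronger inhibition), compound 1 gives 13 nM, the second highest of the three numbers measured. Compound 2 `CN1CCC(c2c[nH]c3ccc(NC(=O)C4CCCCC4)nc23)CC1` gives 20 nM in this assay, and compound 3 `Cc1cccc(C(=O)Nc2ccc3[nH]cc(C4CCN(C)CC4)c3n2)c1` gives 5.8 nM. The step of a 1.5-fold higher number from compound 1 to compound 2 (0.19 log units; within the scatter) stays within the scatter, while a 2.2-fold lower number from compound 1 to compound 3 (0.35 log units; beyond the scatter) and a 3.4-fold lower number from compound 2 to compound 3 (0.54 log units; beyond the scatter) are modest. Compound 4 `CCCCC(=O)Nc1ccc2[nH]cc(C3CCN(C)CC3)c2n1` differs from compound 1 by hydrogen in place of methyl on a saturated chain carbon, four bonds along the chain from a carbonyl carbon. Going by the values given here, none of the measured steps is of this kind; the only step that keeps a saturated group on the carbonyl carbon, a 1.5-fold higher number from compound 1 to compound 2 (0.19 log units; within the scatter), stays within the scatter, so a step within the scatter is expected. The expected step is a 1.2-fold higher number from compound 1 to compound 4 (0.06 log units; within the scatter). Compound 4 is estimated at 15 nM, with a range from 7 nM to 35 nM.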

Compound 4, inhibition constant: 14 nM
Beside the measured number, compound 4's estimate is 1.1-fold (0.03 log units) above it; the range from low to high includes it.
By their numbers in this assay, from the lowest: compound 3; then compounds 1, 4 and 2 (each within the scatter of the next).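

Hydrogen in place of methyl at this chain end leaves the number within the scatter, with a 1.1-fold higher number from compound 1 to compound 4 (0.03 log units; within the scatter), so pentyl and butyl on the carbonyl carbon cannot be told apart here. Butyl also cannot be told apart from cyclohexyl, with a 1.4-fold lower number from compound 2 to compound 4 (0.15 log units; within the scatter), while 3-methylphenyl stays separate from butyl, with a 2.4-fold higher number from compound 3 to compound 4 (0.38 log units; beyond the scatter), so among these compounds only 3-methylphenyl stands apart from the saturated groups. No supporting data bear on these results. Still open, going by these compounds, is whether propyl or a chain longer than pentyl would stay within the scatter, and how unsubstituted phenyl would compare with 3-methylphenyl.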